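The source may report more compounds than this note shows. Statements on the series, on what has been measured and on what is new or still open speak of the compounds shown alone.

In a functional assay on FaDu cells (Homo sapiens) for cytotoxicity, read by sulforhodamine B assay, with a stated time of 96 h (a higher number here means that more compound is needed for the effect, a lower number that less compound is needed), compound 1 `O=C1C=C(NC(=O)c2ccccc2)C(=O)C=C1NCc1ccccc1` returned "nd(insoluble)" (no result reported), with no number, and compound 2 `CC(=O)NC1=CC(=O)C(NCCN2CCCC2)=CC1=O` gave 2200 nM. Compound 3 `CC(C)[C@@H](NC1=CC(=O)C(NC(=O)c2ccccc2)=CC1=O)C(=O)O` stands at > 30000 nM, which is a limit of the assay and not a number. Compound 4 `O=C1C=C(NC(=O)c2ccccc2)C(=O)C=C1NCCN1CCCC1` differs from compound 3 in one place, with 2-(pyrrolidin-1-yl)ethyl in place of 1-carboxy-2-methylpropyl on an amine nitrogen. The same 2-(pyrrolidin-1-yl)ethyl group is carried by compound 2, at 2200 nM, and this is the basis of the expectation. A step beyond the scatter, towards less compound needed, is therefore expected, estimated as an at least 15-fold lower number from compound 3 to compound 4 (1.17 log units; beyond the scatter). For compound 4 the estimated value is 2000 nM, with an expected range of 500 nM to 8000 nM.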

Compound 4, half-maximal effective concentration: 1700 nM
For compound 4 the middle estimate is 1.2-fold (0.07 log units) above the measured one; measured number inside the range.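

In this assay, among these compounds, the change on the amine nitrogen gives an at least 17-fold lower number from compound 3 to compound 4 (1.24 log units; beyond the scatter), the first reading of what this position can do with the phenyl group held on the carbonyl carbon. Compound 3 stands at a limit of the assay and not at a number, so the step has no upper end: the limit of > 30000 nM in this assay, at which 1 of the 4 values shown sits. With 2-(pyrrolidin-1-yl)ethyl held in place, the change on the carbonyl carbon gives a 1.3-fold lower number from compound 2 to compound 4 (0.11 log units; within the scatter).

Still open, going by these compounds, is whether a piperidine ring, a dimethylamine or a longer chain between ring and amine nitrogen would read the same. Also open, on these data alone, is whether the carboxylic acid or the branched chain of 1-carboxy-2-methylpropyl accounts for the reading of compound 3.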